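A few compounds are considered here, and "the series" means these few. Any claim that something is new, unique, unknown or untested is made for them only; others in the source may bear on it.

Compound 1 `O=C(NCc1ccc(CNS(=O)(=O)c2ccccc2)cc1)c1ccc([N+](=O)[O-])cc1` is one of three compounds that share a core and differ in the aryl group on the carbonyl carbon. In an assay on MDA-MB-231 cells for binding affinity to C-X-C chemokine receptor type 4 (Homo sapiens), read by immunofluorescence and microscopy, with stated times of 10 min and 30 min (on this read-out lower numbers stand for an effect already at smaller amounts and higher numbers for an effect only at larger amounts of compound), compound 1 gives 100 nM, the highest of the two numbers shown. Compound 2 `Cc1ccc(S(=O)(=O)NCc2ccc(CNC(=O)c3cccc(F)c3)cc2)cc1` gives 1 nM. For compound 3 `Cc1ccc(S(=O)(=O)NCc2ccc(CNC(=O)c3cccnc3)cc2)cc1` only a limit is reported, > 1000 nM. Going by the values given here, the one measured step, an at least 1000-fold higher number from compound 2 to compound 3 (3.00 log units; beyond the scatter), is large (the limit of > 1000 nM in this assay, at which 1 of the 3 values shown sits). Compound 4 `O=C(NCc1ccc(CNS(=O)(=O)c2ccccc2)cc1)c1ccccc1F` is not yet measured; it differs from compound 1 by 2-fluorophenyl in place of 4-nitrophenyl on a carbonyl carbon. Among the compounds with values here, no measured step covers this exact exchange, and compound 2 carries a different sulfonyl aryl, so its number is only a loose guide. A moderate decrease is expected, a 3.3-fold lower number from compound 1 to compound 4 (0.52 log units; beyond the scatter), giving compound 4 an estimated 30 nM, between 3 nM and 300 nM.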

Compound 4, effective concentration (reported as EC, without a stated level of effect): 1000 nM
Compound 4: the middle estimate sits 33-fold (1.52 log units) below what was measured; the measured number lies above the stated range.
By their numbers in this assay, from the lowest: compound 2; then compound 1; then compound 4.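

On the core of compound 1, the exchange on the carbonyl carbon also moves the result in this assay, giving a 10-fold higher number from compound 1 to compound 4 (1.00 log units; beyond the scatter). A fluorine-bearing aryl group at this place therefore does not bring a low number by itself, even though compound 2 gives 1 nM. Compound 2 also carries a different sulfonyl aryl, so it differs from compound 4 in more than one place and the two cannot be compared directly.

Compound 3 remains a limit and not a number: the limit of > 1000 nM in this assay, at which 1 of the 4 values shown sits. From the compounds shown here alone, how an aryl group carrying an amine or a carboxylic acid would behave on this carbonyl carbon stays open.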